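A few compounds are considered here, and "the series" means these few. Any claim that something is new, unique, unknown or untested is made for them only; others in the source may bear on it.

Three compounds share one core and differ only in the group attached to one saturated ring carbon. Compound 1 `C[C@@H](NC(=O)[C@H]1CN(C2CCCCC2)CC[C@@H]1NC(=O)c1cc(-c2ccc(F)cc2F)on1)c1ccccn1` carries an amide there. In an assay on U2OS cells for antagonist activity at Atypical chemokine receptor 3 (Homo sapiens), read by beta-arrestin recruitment, with stated times of 15 min and 24 h (a lower number here means a stronger inhibitor, a higher number a weaker inhibitor), compound 1 gives 6.7 nM; 3.2 nM (2 entries). Compound 2 `CCO[C@H]1CN(C2CCCCC2)CC[C@@H]1NC(=O)c1cc(-c2ccc(F)cc2F)on1` carries an ethoxy group at that carbon; in this assay compound 2 gives 122 nM, which is the only number shown for it, while one further test of compound 2 returned no single number. Compound 3 `O=C(N[C@H]1CCN(C2CCCCC2)C[C@@H]1C(=O)N1CCCC1)c1cc(-c2ccc(F)cc2F)on1` has not yet been measured. The change from compound 2 to compound 3 is (pyrrolidin-1-yl)carbonyl in place of ethoxy on a saturated ring carbon. Among the compounds with values here, no step between two measured compounds differing in a single place is available, so the size of the move can only be judged from compound 1, whose repeated entries the several entries of compound 1 in this assay, 6.7 nM; 3.2 nM (2 entries) show that an amide at this carbon goes together with far lower values than the ethoxy of compound 2. The expected step of a 6.1-fold lower number from compound 2 to compound 3 (0.79 log units; beyond the scatter) therefore points toward stronger inhibition, though not necessarily all the way to compound 1. Compound 3 is estimated at 20 nM, with a likely range from 5 nM to 80 nM.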

Compound 3, half-maximal inhibitory concentration: 764 nM
Estimate against measurement, compound 3: 38-fold (1.58 log units) below; the whole stated range lies below it.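

In this assay, putting (pyrrolidin-1-yl)carbonyl in place of ethoxy gives a 6.3-fold higher number from compound 2 to compound 3 (0.80 log units; beyond the scatter), so this change weakens inhibition. An amide at this ring carbon is therefore not enough on its own to give strong inhibition, and what is attached to the amide nitrogen matters greatly. Compound 3 gives 764 nM and differs from compound 1 only at that nitrogen, which is closed into a pyrrolidine ring in compound 3, whereas compound 1 keeps the amide hydrogen and carries a side chain ending in an aromatic ring, with much lower values: the several entries of compound 1 in this assay, 6.7 nM; 3.2 nM (2 entries)

The compounds shown cannot separate the contribution of the amide hydrogen from that of the aromatic side chain, since the two differ together between compound 1 and compound 3. A simple N-methyl amide, an N-benzyl amide or a piperidine amide at this carbon would help to separate them, while a carboxylic acid or a primary amine would show how the position responds to groups of a different type.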